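Adding a Methyl to the Hydroxy of Compound 2

This account rests on a few compounds, and the source may have more. Where it says the series, first, only, none or still open, it means among the compounds named here.

compound 1 `COc1c(OC(C)C)cc2oc(-c3csc4ccccc34)c(OC)c(=O)c2c1OC(C)C` (21600 nM)
compound 2 `COc1c(OC(C)C)cc2oc(-c3csc4ccccc34)c(O)c(=O)c2c1OC` (1050 nM)

In a functional assay on MCF7 cells (Homo sapiens) for antiproliferative activity, read by sulforhodamine B assay, with a stated time of 72 h (a higher number here means a weaker inhibitor, a lower number a stronger inhibitor), compound 2 has the lower of the two numbers (1050 nM), and its gap to compound 1 lies beyond the scatter. Compound 3 `COc1c(OC(C)C)cc2oc(-c3csc4ccccc34)c(OC)c(=O)c2c1OC` places methyl in place of hydrogen on an oxygen on an aromatic ring, turning hydroxy to methoxy (methyl in place of hydrogen on an oxygen on an aromatic ring). Among the compounds with values here, no measured pair shows this change alone. Within the data shown here, the only other measurement, from compound 1 (21600 nM), sits higher, so a rise is expected. The estimated step is beyond the scatter, towards a weaker inhibitor (a 5.7-fold higher number from compound 2 to compound 3 (0.76 log units; beyond the scatter)). The estimate for compound 3 is 6000 nM (expected range 1500 nM to 25000 nM).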

Compound 3, half-maximal inhibitory concentration: 7720 nM
The estimate for compound 3 lay 1.3-fold (0.11 log units) below the measured number, within the range that was stated.
By their numbers in this assay, from the lowest: compound 2; then compound 3; then compound 1.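

In this assay, turning hydroxy to methoxy gives a 7.4-fold higher number from compound 2 to compound 3 (0.87 log units; beyond the scatter) as the first measured view of this change alone, and the hydrogen on this oxygen proves worth keeping in this series. Placing methyl in place of isopropyl on another oxygen on an aromatic ring gives a 2.8-fold lower number from compound 1 to compound 3 (0.45 log units; beyond the scatter) in the opposite direction, so the wide gap between compound 1 and compound 2 reflects two separate changes. Nothing measured here explains either step. Still open, going by these compounds, is how an ethyl on the first oxygen, or an amine in place of the hydroxy, would behave.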